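The compounds below may be only part of what the source reports. "The series", "measured", "known", "first", "only" and "open" are said of these compounds alone.

- compound 1 `O=C(NN1CCOC1=O)c1[nH]c2ccc(Cl)cc2c1S(=O)(=O)c1ccccc1`: > 100 uM
- compound 2 `Cc1cc(C)cc(S(=O)(=O)c2c(C(=O)NNC(C)C)[nH]c3ccc(Cl)cc23)c1`: > 100 uM

Both readings come from a functional assay on MT4 cells (Homo sapiens) for cytotoxicity, read by MTT assay; on this read-out higher numbers stand for lower toxicity in this test and lower numbers for higher toxicity in this test. Compound 1 gives > 100 uM, which is a limit of the assay and not a number. Compound 2 gives > 100 uM, which is likewise a limit. Going by the values given here, compound 2 therefore stands with the only other measured compound at the top of the measurable range: the limit of > 100 uM in this assay, at which 2 of the 2 values shown sit.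

The next compound is compound 3 `Cc1cc(C)cc(S(=O)(=O)c2c(C(=O)NNC(=O)NN)[nH]c3ccc(Cl)cc23)c1`. The structural change is aminocarbamoyl in place of isopropyl on an amine nitrogen. Among the compounds with values here, no step between measured compounds is available to size this change, and neither of the two readings is a number.

The estimated step of an at least 1.2-fold lower number from compound 2 to compound 3 (0.09 log units; that floor lies within the scatter) is expected to stay within the usual scatter, with any movement toward lower numbers. That expectation rests on compound 2, whose limit is > 100 uM. A further limit in place of a number is expected slightly more often than not. For compound 3 the expected half-maximal toxic concentration is 80 uM, with an estimated range of 25 uM to 200 uM.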

Compound 3, half-maximal toxic concentration: > 100 uM
Compound 3 was reported as a limit (the forecaster's own chance of this, stated with the estimate: 55%); middle value at least 1.2-fold (0.09 log units) from the limit.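

In this assay compound 3 gives > 100 uM as a limit and not a number. Compound 2 also reads only as a limit, so no step can be read from compound 2 to compound 3. All compounds shown sit at the same point: the limit of > 100 uM in this assay, at which 3 of the 3 values shown sit.

Going by these compounds, how far any of them lies beyond that limit, and whether aminocarbamoyl in place of isopropyl changes the reading at all, stays open.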